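Long-chain alkyne ethers at the limit of cytotoxicity

The source may report more compounds than this note shows. Statements on the series, on what has been measured and on what is new or still open speak of the compounds shown alone.

Measured in an ADME assay on DU-145 cells (Homo sapiens) for cytotoxicity, read by sulforhodamine B assay, with a stated time of 48 h; a lower number here means a stronger inhibitor, a higher number a weaker inhibitor:
compound 1 `C#CCOCCOCCOCCOCCOCCOCCOc1ccc(-c2nc3ccc(-c4nc5ccc(N6CCN(C)CC6)cc5[nH]4)cc3[nH]2)cc1`: > 10000 nM
compound 2 `C#CCCCCCCCCCOc1ccc(-c2nc3ccc(-c4nc5ccc(N6CCN(C)CC6)cc5[nH]4)cc3[nH]2)cc1`: > 10000 nM

Compound 2 stands at > 10000 nM, which is a limit of this assay and not a number. Compound 1 also gives only a limit, > 10000 nM. Among the compounds with values here, no measured step is available, and the data so far consist of the limit of > 10000 nM in this assay, at which 2 of the 2 values shown sit.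

Compound 3 `C#CCOCCCCCCCCCCCCOc1ccc(-c2nc3ccc(-c4nc5ccc(N6CCN(C)CC6)cc5[nH]4)cc3[nH]2)cc1` keeps the shared core of compound 2 and alters the end of the chain: 3-(propargyloxy)propyl in place of ethynyl on a saturated chain carbon, nine bonds along the chain from an oxygen on an aromatic ring. In words, 3-(propargyloxy)propyl stands in place of ethynyl on a saturated chain carbon, nine bonds along the chain from an oxygen on an aromatic ring. The triple bond outside aromatic rings is kept.

The expectation rests on compound 2 at > 10000 nM, a limit from which no direction can be read. The expected change is a step that the limit leaves unreadable from compound 2 to compound 3, estimated to stay within the scatter, with no direction. Compound 3 is expected at 12000 nM, with an estimated range from 5000 nM to 30000 nM.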

Compound 3, half-maximal inhibitory concentration: > 10000 nM
Compound 3: only a limit was reported; the forecaster's own chance of this, stated with the estimate: 80%; the middle value lies beyond the limit too.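

In this assay compound 3 gives > 10000 nM, which is a limit and not a number. No new step can be read from compound 2 to compound 3, because both values are limits: the limit of > 10000 nM in this assay, at which 3 of the 3 values shown sit.

The compounds shown leave open whether swapping ethynyl for 3-(propargyloxy)propyl changes the read-out in this assay at all.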